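Swapping carbonyl for sulfonyl on the shared core

The source may report more compounds than this note shows. Statements on the series, on what has been measured and on what is new or still open speak of the compounds shown alone.

In a functional assay on ID8 cells (Mus musculus) for antiproliferative activity (a higher number here means a weaker inhibitor, a lower number a stronger inhibitor), compound 1 `Cc1ccc(C(=O)Nc2ccc(O)c3c(=O)cc(-c4ccccc4Cl)oc23)cc1` gives 16000 nM. This is the lower of the two numbers available, as compound 3 `C[C@@H](NC(=O)OC(C)(C)C)C(=O)Nc1ccc(O)c2c(=O)cc(-c3ccccc3Cl)oc12` gives 104000 nM. The entry for compound 2 `Cc1ccc(C(=O)Nc2c(O)cc(O)c3c(=O)cc(-c4ccccc4Cl)oc23)cc1` reads "not determined" (no result reported), so it offers no comparison.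

Compound 4 `O=c1cc(-c2ccccc2Cl)oc2c(NS(=O)(=O)c3ccccc3)ccc(O)c12` has yet to be measured. Its difference from compound 1 is phenylsulfonyl in place of (4-methylphenyl)carbonyl on a nitrogen on an aromatic ring. Phenylsulfonyl stands in place of (4-methylphenyl)carbonyl on a nitrogen on an aromatic ring, and each group carries one six-membered aromatic ring of carbon only.

Among the measured compounds shown here, only one measured step bears on this change, and only indirectly: a 6.5-fold higher number from compound 1 to compound 3 (0.81 log units; beyond the scatter). There, 1-((tert-butoxycarbonyl)amino)ethyl replaced 4-methylphenyl on a carbonyl carbon, so the aromatic ring of that group was lost. For the measured compounds named here, compound 4 keeps such a ring but has no carbonyl in that group, and no measured compound shows what that exchange does. Going by the values given here, a step as large as the one to compound 3 is therefore not expected, and only a slight rise in this assay is anticipated, within the scatter. The estimated step is a 1.3-fold higher number from compound 1 to compound 4 (0.10 log units; within the scatter). Compound 4 is expected at 20000 nM, with an estimated range from 6000 nM to 70000 nM.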

Compound 4, half-maximal inhibitory concentration: 9500 nM
For compound 4 the middle estimate is 2.1-fold (0.32 log units) above the measured one, within the range that was stated.
By their numbers in this assay, from the lowest: compounds 4 and 1 (each within the scatter of the next); then compound 3.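

In this assay the exchange of (4-methylphenyl)carbonyl for phenylsulfonyl on a nitrogen on an aromatic ring gives a 1.7-fold lower number from compound 1 to compound 4 (0.23 log units; within the scatter) and stays within the scatter, so compound 1 and compound 4 cannot be told apart, and this position accepts a sulfonyl in place of the carbonyl without a measurable shift. The earlier step, a 6.5-fold higher number from compound 1 to compound 3 (0.81 log units; beyond the scatter) and beyond the scatter, removed the aromatic ring from the group while the carbonyl stayed, whereas here the group keeps one six-membered aromatic ring of carbon only while the carbonyl goes. Nothing at hand explains why the number holds across this exchange.

The exchange in compound 4 also drops the methyl from the aromatic ring, so the compounds shown do not separate the effect of the sulfonyl from that of the methyl, which a 4-methylphenylsulfonyl group on the same nitrogen would address. They also leave open how the sulfonyl position responds when its aromatic ring carries an amine or a carboxylic acid, or when a simple alkyl chain replaces that ring.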